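The source may report more compounds than this note shows. Statements on the series, on what has been measured and on what is new or still open speak of the compounds shown alone.

Compound 1, `CN(C)c1cccc(Oc2ccc3c(NCCCNCc4ccco4)ccnc3c2)c1`, in a physicochemical assay for acid dissociation, gives 9.28.
Compound 2, `Clc1ccc(Oc2ccc3c(NCCCNCc4ccco4)ccnc3c2)cc1`, in this assay gives 9.28.

Compound 2 stands level with compound 1 on the numbers shown: the step of no change at the digits printed from compound 1 to compound 2 (within the scatter) lies within the scatter. Compound 3, `COc1ccc(Oc2ccc3c(NCCCNCc4ccco4)ccnc3c2)cc1`, is not yet measured. It differs from compound 2 as follows: methoxy in place of chloro on an aromatic carbon. Within the data shown here, the one measured step that bears on this change is no change at the digits printed from compound 1 to compound 2 (within the scatter), which exchanged one substituted phenyl group for another on the oxygen on the aromatic ring and left the acid dissociation constant unchanged. A further exchange of the substituent on that same phenyl group is therefore expected to bring no step beyond the scatter, so the expected step is no change at the digits printed from compound 2 to compound 3 (within the scatter). Compound 3 is estimated to give 9.28 in this assay, with an expected range from 8.98 to 9.58.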

Compound 3, acid dissociation constant: 9.28
For compound 3 middle estimate and measured number coincide at the digits printed; measured number inside the range.
By their numbers in this assay, from the lowest: compounds 1, 2 and 3 (each within the scatter of the next).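

Compound 3 isolates a single exchange that the earlier pair did not: methoxy in place of chloro on an aromatic carbon, para to a large group, with the rest of the phenyl group held fixed, and this assay shows no change at the digits printed from compound 2 to compound 3 (within the scatter). The exchange of the whole substituted phenyl group on the oxygen gives a matching result, with no change at the digits printed from compound 1 to compound 3 (within the scatter), so 3-(dimethylamino)phenyl, 4-chlorophenyl and 4-methoxyphenyl cannot be told apart by this read-out. No measurement shown explains why the number stays level.

Going by these compounds, whether a carboxylic acid or a primary amine on this phenyl group would also leave the number level remains open. All three compounds share the rest of the structure, so the effect of a longer chain in the amine-bearing side chain is also unknown.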